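Swapping 4-chlorophenyl for ethyl on the carbonyl carbon

This account rests on a few compounds, and the source may have more. Where it says the series, first, only, none or still open, it means among the compounds named here.

In a functional assay on ACHN cells (Homo sapiens) for cytotoxicity, read by sulforhodamine B assay, with a stated time of 72 h (on this read-out lower numbers stand for stronger inhibition of growth and higher numbers for weaker inhibition of growth), compound 3 `O=C(Nc1cc(C(F)(F)F)cc(C(F)(F)F)c1)C1CCc2ccccc2N1C(=O)c1ccc(Cl)cc1` gives 2570 nM, the lowest of the two actual numbers shown. The other number is that of compound 2 `CCCC(=O)N1c2ccccc2CCC1C(=O)Nc1cc(C(F)(F)F)cc(C(F)(F)F)c1`, which gives 13900 nM. For compound 1 `CC(=O)N1c2ccccc2CCC1C(=O)Nc1cc(C(F)(F)F)cc(C(F)(F)F)c1` the assay reports only a limit, > 70000 nM.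

Compound 4 `CCC(=O)N1c2ccccc2CCC1C(=O)Nc1cc(C(F)(F)F)cc(C(F)(F)F)c1` has ethyl in place of 4-chlorophenyl on a carbonyl carbon whose other neighbour is an amide-type nitrogen in a ring (ethyl in place of 4-chlorophenyl on a carbonyl carbon). Two measured steps change the same place in the opposite direction. With 4-chlorophenyl in place of propyl, the change is a 5.4-fold lower number from compound 2 to compound 3 (0.73 log units; beyond the scatter). With 4-chlorophenyl in place of methyl, it is an at least 27-fold lower number from compound 1 to compound 3 (1.43 log units; beyond the scatter). Chain length also counted, with an at least 5.0-fold lower number from compound 1 to compound 2 (0.70 log units; beyond the scatter). Ethyl is longer than methyl and shorter than propyl, so this assay should move to a higher number, by a step at least as large as the modest one and possibly approaching the large one. The expected change is a 12-fold higher number from compound 3 to compound 4 (1.07 log units; beyond the scatter), beyond the scatter. For compound 4 the estimate is 30000 nM, with an expected range of 14000 nM to 70000 nM.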

Compound 4, concentration for 50% growth inhibition: 7720 nM
Compound 4: middle estimate off by 3.9-fold (0.59 log units), on the high side; measured number outside the range, below it.
By their numbers in this assay, from the lowest: compound 3; then compounds 4 and 2 (each within the scatter of the next). At a limit, above all of these: compound 1.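

In this assay the 4-chlorophenyl group keeps its advantage over ethyl on this carbonyl carbon, with a 3.0-fold higher number from compound 3 to compound 4 (0.48 log units; beyond the scatter), but that advantage is only modest. Going from ethyl to propyl gives no change that can be told apart, with a 1.8-fold lower number from compound 2 to compound 4 (0.26 log units; within the scatter), so among these chains the clear gain lies in the step from acetyl to propanoyl. That step is an at least 9.0-fold lower number from compound 1 to compound 4 (0.95 log units; beyond the scatter), and it starts from a limit: the limit of > 70000 nM in this assay, at which 1 of the 4 values shown sits.

The compounds shown leave open whether a chain longer than propyl, such as hexyl, would stay level with compounds 2 and 4 or come closer to compound 3, and whether the chlorine counts at all, which a plain phenyl group would test. They also leave open how a branched chain such as isopropyl or a saturated ring such as cyclohexyl would compare at this carbonyl carbon.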